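A few compounds are considered here, and "the series" means these few. Any claim that something is new, unique, unknown or untested is made for them only; others in the source may bear on it.

Series notes, cytotoxicity.

Compound 3 `COC(=O)N[C@H](C(=O)NN(CCC[C@@](O)(Cc1ccccc1)C(=O)N[C@H]1c2ccccc2C[C@H]1O)Cc1ccc(-c2cncnc2)cc1)C(C)(C)C` is the anchor of this step. In an ADME assay on MT4 cells (Homo sapiens) for cytotoxicity (on this read-out lower numbers stand for higher toxicity in this test and higher numbers for lower toxicity in this test), compound 3 gives > 10000 nM, which is a limit of the assay rather than a number. Among the measured compounds shown here, the two other compounds measured so far stand the same way. Compound 1 `COC(=O)N[C@H](C(=O)NN(CCC[C@](O)(Cc1ccccc1)C(=O)N[C@H]1c2ccccc2C[C@H]1O)Cc1ccc(Br)cc1)C(C)(C)C` gives > 10000 nM in this assay, again a limit. Compound 2 `COC(=O)N[C@H](C(=O)NN(CCC[C@@](O)(Cc1ccccc1)C(=O)N[C@H]1c2ccccc2C[C@H]1O)CC(C)C)C(C)(C)C` gives > 10000 nM in this assay, also a limit. For the measured compounds named here, the only single-point comparison among them, a step that the two limits leave unreadable from compound 2 to compound 3, cannot be read because the limit of > 10000 nM in this assay, at which 3 of the 3 values shown sit, is where both of its values sit.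

Compound 4 `COC(=O)N[C@H](C(=O)NN(CCC[C@@](O)(Cc1ccccc1)C(=O)N[C@H]1c2ccccc2C[C@H]1O)Cc1ccc(OCc2cnc(Cl)s2)cc1)C(C)(C)C` is not yet measured. It differs from compound 3 by (2-chloro-1,3-thiazol-5-yl)methoxy in place of pyrimidin-5-yl on an aromatic carbon. Going by the values given here, no measured step in this assay bears on this exchange: the one step that exists between measured compounds is unreadable, and nothing else among the three compounds touches the group that changes here. What the series does show is that three different substituents on the saturated chain carbon bound to the amine nitrogen, including the 4-(pyrimidin-5-yl)phenyl of compound 3, all leave the cytotoxicity at the limit.

The expectation is therefore no readable step: a step that the limit leaves unreadable from compound 3 to compound 4 is the estimated step, and compound 4 is expected to return 20000 nM in this assay, within the range 7000 nM to 60000 nM, most likely again as a limit rather than a number.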

Compound 4, half-maximal cytotoxic concentration: > 10000 nM
Compound 4 was reported as a limit; the forecaster's own chance of this, stated with the estimate: 85%; the middle value does not contradict the limit.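

In this assay compound 4 gives > 10000 nM, a limit of the assay. No step can be read between compound 3 and compound 4, because both sit at the same limit: the limit of > 10000 nM in this assay, at which 4 of the 4 values shown sit. The compounds shown leave open whether any of the exchanged groups alters the read-out in this assay, as none of the four gives a number.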